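The source may hold more compounds than are shown below. What is called first, only, known or untested is meant among the compounds shown, and "the series" means these compounds.

In a functional assay on cells (Panel prostate (Carcinoma cell lines), Homo sapiens) for inhibition (a lower number here means a stronger inhibitor of growth, a higher number a weaker inhibitor of growth), compound 1 (`CN1C/C(=C\c2cccs2)C2=NN(C)C(c3cccs3)C2C1`) gives > 100000 nM, which is a limit of the assay and not a number. Among the measured compounds shown here, the only true number so far in this assay comes from compound 2 (`Cc1ccc(/C=C2\CN(C)CC3=C2OC(N)=C(C#N)C3c2ccc(C)cc2)cc1`), which gives 66200 nM.

Compound 3 (`CN1C/C(=C\c2cccs2)C2=NN(c3ccccc3)C(c3cccs3)C2C1`) keeps the core of compound 1 but has phenyl in place of methyl on an amine nitrogen in a ring. For the measured compounds named here, no measured pair of compounds shows what this swap does, so any forecast here is loose. Going by the values given here, with compound 2 at 66200 nM as the sole guide, only a modest gain is expected, and compound 3 could still fail to give a number. The expected at least 1.4-fold lower number from compound 1 to compound 3 (0.15 log units; that floor lies within the scatter) is small and points towards stronger growth inhibition. For compound 3 the estimated value is 70000 nM, with an expected range of 25000 nM to 100000 nM.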

Compound 3, concentration for total growth inhibition: > 100000 nM
Compound 3: no number, only a limit; the forecaster's own chance of this, stated with the estimate: 45%; at least 1.4-fold (0.15 log units) between middle value and limit.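

Compound 3 gives > 100000 nM as a limit of the assay and not a number. Compound 1 also gives only a limit, so no step can be read from compound 1 to compound 3: the limit of > 100000 nM in this assay, at which 2 of the 3 values shown sit. The compounds shown leave open whether phenyl in place of methyl changes growth inhibition at all.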